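The source may report more compounds than this note shows. Statements on the series, on what has been measured and on what is new or still open speak of the compounds shown alone.

Of the compounds shown here, three of one series have so far been tested in an ADME assay on PA-1 cells (Homo sapiens) for cytotoxicity, read by MTT assay, with a stated time of 72 h; a higher number here means a weaker inhibitor, a lower number a stronger inhibitor. Compound 1 `COc1ccc(C2=C(c3cc(OC)c(OC)c(OC)c3)C(=O)C(OC(C)=O)C2)cc1F` reaches only a limit there, giving > 100 ug/mL. Compound 2 `COc1ccc(C2=C(c3cc(OC)c(OC)c(OC)c3)C(=O)CC2O[SiH2]C(C)(C)C)cc1OC` likewise stops at a limit in this assay, with > 100 ug/mL. Compound 3 `COc1ccc(C2=C(c3cc(OC)c(OC)c(OC)c3)C(=O)C(O)C2)cc1NC(=O)c1ccccc1` also returns a limit, > 100 ug/mL. Compound 2 thus stands exactly where the other measured compounds stand, at the limit of > 100 ug/mL in this assay, at which 3 of the 3 values shown sit, and no number separates it from them. Compound 4 `COc1cc(C2=C(c3ccccc3)C(O[SiH2]C(C)(C)C)CC2=O)cc(OC)c1OC` is not yet measured; it differs from compound 2 by phenyl in place of 3,4-dimethoxyphenyl on a double-bonded ring carbon. With all three known values sitting at the same limit, no step beyond the scatter is expected in this assay, in either direction. The value expected for compound 4 is 150 ug/mL, with a range from 60 ug/mL to 400 ug/mL, which would mean an expected step that the limit leaves unreadable from compound 2 to compound 4.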

Compound 4, half-maximal inhibitory concentration: > 100 ug/mL
Compound 4: only a limit was reported; the forecaster's own chance of this, stated with the estimate: 80%; the middle value lies beyond the limit too.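

In this assay, going by these compounds alone, compound 4 gives > 100 ug/mL, a limit, and compound 2 also stands at a limit, so no step between them can be read. The compounds shown leave open whether phenyl and 3,4-dimethoxyphenyl differ at all in cytotoxicity: the limit of > 100 ug/mL in this assay, at which 4 of the 4 values shown sit.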